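The source may report more compounds than this note shows. Statements on the series, on what has been measured and on what is new or still open speak of the compounds shown alone.

In a functional assay on PC-3 cells (Homo sapiens) for inhibition (on this read-out lower numbers stand for stronger inhibition and higher numbers for weaker inhibition), compound 3 `COc1ccc(-c2oc(O)nc2-c2cc(OC)c(OC)c(OC)c2)cc1O` gives 6.4 nM, the lowest of the three numbers shown. Compound 2 `COc1cc(-c2nc(O)oc2-c2ccc3ccccc3c2)cc(OC)c1OC` gives 7.1 nM, which sits within the scatter of compound 3, while compound 1 `COc1ccc(-c2oc(O)nc2-c2cc(OC)c(OC)c(OC)c2)cc1` gives 20.1 nM. Within the data shown here, the only step that touches the position in question is a 3.1-fold lower number from compound 1 to compound 3 (0.50 log units; beyond the scatter). Compound 4 `COc1ccc(-c2oc(O)nc2-c2cc(OC)c(OC)c(OC)c2)cc1N` is not yet measured; it differs from compound 3 by amino in place of hydroxy on an aromatic carbon. Among the measured compounds shown here, the step from hydrogen to hydroxy is the one measured change at this place, and no measured step shows an amino there, so the data give no direct guide to its size. Compound 4 is therefore expected to stay near compound 3, with a 1.6-fold higher number from compound 3 to compound 4 (0.19 log units; within the scatter) within the scatter, and its estimated value is 10 nM, in a range from 3 nM to 35 nM.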

Compound 4, half-maximal inhibitory concentration: 2.1 nM
Beside the measured number, compound 4's estimate is 4.8-fold (0.68 log units) above it, outside the stated range (below it).
By their numbers in this assay, from the lowest: compound 4; then compounds 3 and 2 (each within the scatter of the next); then compound 1.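

In this assay, the place on the aromatic carbon ortho to the methoxy group proves sensitive to which group sits there, not only to whether one does: the change from 3-hydroxy-4-methoxyphenyl to 3-amino-4-methoxyphenyl gives a 3.0-fold lower number from compound 3 to compound 4 (0.48 log units; beyond the scatter). Measured against hydrogen, amino gives a 9.6-fold lower number from compound 1 to compound 4 (0.98 log units; beyond the scatter), a larger step than the one hydroxy gives, a 3.1-fold lower number from compound 1 to compound 3 (0.50 log units; beyond the scatter). Nothing measured here accounts for the difference between the two groups. Going by these compounds, whether a methylamino group, an acetamido group or a fluorine at this place would lower the number further remains open.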